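The source may report more compounds than this note shows. Statements on the series, on what has been measured and on what is new or still open speak of the compounds shown alone.

Compound 1 `COc1ccccc1OCC1SCCN1C(=O)CN`: 57 mg/kg
Compound 2 `COc1ccccc1OCC1SCCN1C(=O)Cn1ccnc1`: 50 mg/kg
Compound 3 `COc1ccc(OCC2SCCN2C(=O)Cn2ccnc2)cc1`: 48 mg/kg

In a functional assay on the whole organism for inhibition, with Cavia porcellus as the target (a lower number here means that less compound is needed, a higher number that more compound is needed for the effect), compound 1 gives 57 mg/kg, the largest of the three numbers shown, yet compound 2 with 50 mg/kg and compound 3 with 48 mg/kg both lie within the scatter of it. Compound 4 `C=CC(=O)N1CCSC1COc1ccccc1OC` is not yet measured. It differs from compound 1 by vinyl in place of aminomethyl on a carbonyl carbon. Among the measured compounds shown here, the only measured step touching this carbonyl carbon, a 1.1-fold lower number from compound 1 to compound 2 (0.06 log units; within the scatter), stays within the scatter; no measured step exchanges aminomethyl for vinyl, so the size of that change is unknown and the range must be set wide. A step of about no change at the digits printed from compound 1 to compound 4 (within the scatter) is expected, none beyond the scatter. Compound 4 is estimated at 57 mg/kg, between 25 mg/kg and 130 mg/kg.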

Compound 4, dose for half-maximal effect: 74 mg/kg
Compound 4: the middle estimate sits 1.3-fold (0.11 log units) below what was measured, within the range that was stated.
By their numbers in this assay, from the lowest: compounds 3, 2, 1 and 4 (each within the scatter of the next).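

In this assay, the carbonyl carbon now carries vinyl with no step beyond the scatter from either earlier group (a 1.3-fold higher number from compound 1 to compound 4 (0.11 log units; within the scatter)) (a 1.5-fold higher number from compound 2 to compound 4 (0.17 log units; within the scatter)). The change removes the hydrogen-bond donor and acceptor counted on aminomethyl, and this read-out does not separate the two groups. No available evidence accounts for this result.

Open, as far as these compounds go, is whether any group at this carbonyl carbon, such as a carboxylic acid or a longer alkyl chain, gives a step beyond the scatter. Also open, from the compounds shown here alone, is how vinyl behaves on the core of compound 3.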